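The source may report more compounds than this note shows. Statements on the series, on what has been measured and on what is new or still open speak of the compounds shown alone.

In a physicochemical assay for lipophilicity, using the shake flask method, at pH 7.4 (a lower number here means a more polar compound, a higher number a more lipophilic compound), compound 3 (`CCC(Oc1ccc(-n2cc(C(F)(F)F)cn2)cc1)c1ccc(C(=O)NCCC(=O)O)cc1`) gives 1.9. Compound 1 (`CCCC(Nc1ccc(-n2cc(C(F)(F)F)cn2)nc1)c1ccc(C(=O)NCCC(=O)O)cc1`), at 2.1, lies within the scatter of it, whereas compound 2 (`CCCC(Oc1ccc(-n2cc(C(F)(F)F)c(C)n2)cc1)c1ccc(C(=O)NCCC(=O)O)cc1`), at 2.8, stands higher, beyond the scatter. Compound 4 (`CC(C)CC(Oc1ccc(-n2cc(C(F)(F)F)cn2)cc1)c1ccc(C(=O)NCCC(=O)O)cc1`) has isopropyl in place of methyl on a saturated chain carbon, two bonds along the chain from an aromatic carbon and an oxygen on an aromatic ring. For the measured compounds named here, no measured pair here differs in one place, so the expectation rests on this change and on compound 2 at 2.8, which shows how high the series reaches. A rise beyond the scatter in this assay is expected, an estimated a number 0.70 log units higher from compound 3 to compound 4 (beyond the scatter). For compound 4 the estimated value is 2.6, with an expected range of 2.2 to 3.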

Compound 4, distribution coefficient: 3.2
The estimate for compound 4 lay 0.60 log units below the measured number; measured number above the stated range.
By their numbers in this assay, from the lowest: compounds 3 and 1 (each within the scatter of the next); then compound 2; then compound 4.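

In this assay, for the compounds shown here, the step of a number 1.30 log units higher from compound 3 to compound 4 (beyond the scatter) is the first reading of a change in one place, and it shows that this chain position strongly moves the number. The change, ethyl to isobutyl when cut one bond further out, takes the group from 1 to 3 heavy atoms, none of them a hydrogen-bond donor or acceptor. Nothing available explains the size of this step. One step cannot separate the effect of branching from that of added carbons. From the compounds shown here alone, an unbranched longer chain, or an amine at the same place, remains open in this assay.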